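Diethyl in Place of Dimethyl on the Amide

A few compounds are considered here, and "the series" means these few. Any claim that something is new, unique, unknown or untested is made for them only; others in the source may bear on it.

Compound 2 `CN(C)C(=O)c1ccc(NC(=S)N2CCC(C(O)(c3ccccc3)c3ccccc3)CC2)cc1` gives 301 nM in a functional assay for antagonist activity at Neuropeptide Y receptor type 2 (Homo sapiens) (on this read-out higher numbers stand for weaker inhibition and lower numbers for stronger inhibition), the higher of the two numbers available, although compound 1 `CCNC(=O)c1ccc(NC(=S)N2CCC(C(O)(c3ccccc3)c3ccccc3)CC2)cc1` at 206 nM sits within the scatter of it. Compound 3 `CCN(CC)C(=O)c1ccc(NC(=S)N2CCC(C(O)(c3ccccc3)c3ccccc3)CC2)cc1` carries diethylamino in place of dimethylamino on a carbonyl carbon. For the measured compounds named here, the only measured step at this place, a 1.5-fold higher number from compound 1 to compound 2 (0.16 log units; within the scatter), was small. A further enlargement of the same amine is therefore expected to move this assay little, perhaps drifting towards a higher number, and not clearly beyond the scatter. Compound 3 is expected to give 420 nM, within the range 150 nM to 1200 nM. That estimate corresponds to an expected step of a 1.4-fold higher number from compound 2 to compound 3 (0.14 log units; within the scatter).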

Compound 3, half-maximal inhibitory concentration: 78 nM
Compound 3: the middle estimate sits 5.4-fold (0.73 log units) above what was measured; the whole stated range lies above it.
By their numbers in this assay, from the lowest: compound 3; then compounds 1 and 2 (each within the scatter of the next).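

In this assay this carbonyl position proves sensitive to the amine it carries, which the first two compounds did not show: diethylamino in place of dimethylamino gives a 3.9-fold lower number from compound 2 to compound 3 (0.59 log units; beyond the scatter) and so clears the scatter. Ethyl in place of hydrogen on the amide-type nitrogen gives a 2.6-fold lower number from compound 1 to compound 3 (0.42 log units; beyond the scatter) as well, so compound 3 stands apart from both earlier compounds. The data offer no measurement that explains this gain. On these data alone, whether dipropylamino, a longer chain, would lower the number further remains open, as does where ethylmethylamino would fall.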